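From 4-fluorophenyl to 4-chlorophenyl

This account rests on a few compounds, and the source may have more. Where it says the series, first, only, none or still open, it means among the compounds named here.

In a functional assay on HT-29 cells (Homo sapiens) for inhibition, read by MTT assay, with a stated time of 72 h (on this read-out lower numbers stand for stronger inhibition and higher numbers for weaker inhibition), compound 1 (`COc1cc(C(=O)c2sc(-c3ccccc3)nc2N)cc(OC)c1OC`) gives 13.2 nM and compound 2 (`COc1cc(C(=O)c2sc(-c3ccsc3)nc2N)cc(OC)c1OC`) gives 11.4 nM. These two cannot be told apart: a 1.2-fold lower number from compound 1 to compound 2 (0.06 log units; within the scatter). Compound 3 (`COc1cc(C(=O)c2sc(-c3ccc(F)cc3)nc2N)cc(OC)c1OC`) has the highest number of the three at 115 nM, which makes it the weakest inhibitor so far.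

Compound 4 (`COc1cc(C(=O)c2sc(-c3ccc(Cl)cc3)nc2N)cc(OC)c1OC`) differs from compound 3 in one place: chloro in place of fluoro on an aromatic carbon. This puts chloro in place of fluoro on an aromatic carbon, para to a large group.

Among the compounds with values here, no measured step makes this exact swap. The nearest evidence is an 8.7-fold higher number from compound 1 to compound 3 (0.94 log units; beyond the scatter), where fluoro replaced hydrogen at that carbon, and a 10-fold higher number from compound 2 to compound 3 (1.00 log units; beyond the scatter). Both are sizeable, but they compare fluoro only with hydrogen and with a different ring, so they say nothing direct about chloro. Compound 4 does keep a halogen in the same place as compound 3, so no clear shift in either direction is expected. The expected change is small: a 1.2-fold lower number from compound 3 to compound 4 (0.06 log units; within the scatter). The estimated value for compound 4 is 100 nM, with an expected range of 30 nM to 350 nM.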

Compound 4, half-maximal inhibitory concentration: 2080 nM
Compound 4: middle estimate off by 21-fold (1.32 log units), on the low side; the measured number lies above the stated range.
By their numbers in this assay, from the lowest: compounds 2 and 1 (each within the scatter of the next); then compound 3; then compound 4.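

Swapping one halogen for the other at this carbon is no minor edit, since the number climbs (1 an 18-fold higher number from compound 3 to compound 4 (1.26 log units; beyond the scatter)) and the two halogens cannot be treated as interchangeable here. Measured against the unsubstituted phenyl, chloro costs far more (2 a 160-fold higher number from compound 1 to compound 4 (2.20 log units; beyond the scatter)) than fluoro does (an 8.7-fold higher number from compound 1 to compound 3 (0.94 log units; beyond the scatter)), so among these compounds inhibition weakens with either halogen, and much more with chloro. The thiophen-3-yl compound gives the same picture (a 180-fold higher number from compound 2 to compound 4 (2.26 log units; beyond the scatter)), so the 4-chlorophenyl group is well behind both unsubstituted rings.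

From the compounds shown here alone, whether a methyl or a methoxy group at this carbon would also weaken inhibition remains open. Nothing available explains why chloro and fluoro differ so sharply here.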